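Swapping an oxazole for a benzoyl on a shared amine

The source may hold more compounds than are shown below. What is called first, only, known or untested is meant among the compounds shown, and "the series" means these compounds.

Measured compounds:
compound 1 `CN(c1ncco1)c1cnc(NCc2c(F)ccc3c2CCO3)n2cnnc12` — 2.1
compound 2 `Cc1ncccc1-c1cnc(NCc2c(F)ccc3c2CCO3)c2ncc(=O)[nH]c12` — 2.8
compound 3 `Cc1ncccc1-c1cnc(NCc2c(F)ccc3c2CCO3)c2cn[nH]c(=O)c12` — 3

Of the compounds shown here, three have been measured in a physicochemical assay for lipophilicity, using the shake flask method, in phosphate buffer, measured as octanol-water partition, with a stated time of 30 min, at pH 7.4; on this read-out higher numbers stand for higher lipophilicity and lower numbers for lower lipophilicity. Compound 1 gives 2.1, the lowest of the three numbers. Compound 2 gives 2.8, and compound 3 gives 3; both of these stand above compound 1 by more than the usual scatter, compound 3 being the furthest away. Compounds 2 and 3 differ from compound 1 in more than one place, so no single step can be read from them, and the two values are only noted as they stand.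

The next compound, compound 4 `CN(C(=O)c1ccccc1)c1cnc(NCc2c(F)ccc3c2CCO3)n2cnnc12`, has not yet been measured. It differs from compound 1 in one place: benzoyl in place of 1,3-oxazol-2-yl on a nitrogen on an aromatic ring. Cut one bond further out, the change reads methyl(1,3-oxazol-2-yl)amino to benzoyl(methyl)amino.

Within the data shown here, no step between two measured compounds differing in one place is available, so the expectation rests on the structural change alone. In this assay compound 4 is expected to move upward from compound 1 by a moderate step, a number 0.60 log units higher from compound 1 to compound 4 (beyond the scatter), beyond the scatter. The estimated value for compound 4 is 2.7, with a range from 2.2 to 3.2.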

Compound 4, distribution coefficient: 2.4
The estimate for compound 4 lay 0.30 log units above the measured number; the range from low to high includes it.
By their numbers in this assay, from the lowest: compounds 1 and 4 (each within the scatter of the next); then compounds 2 and 3 (each within the scatter of the next).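

In this assay, among these compounds, the exchange of 1,3-oxazol-2-yl for benzoyl on a nitrogen on an aromatic ring gives a number 0.30 log units higher from compound 1 to compound 4 (within the scatter) and provides the first step in this set that can be read at a single position. At this position, a five-membered aromatic ring with 2 hetero atoms and a benzoyl group, which brings a six-membered aromatic ring of carbon only, a carbonyl and 8 heavy atoms in place of 5, cannot be told apart on this read-out. Nothing measured here bears on the reason for this result.

The compounds shown leave open whether this position would also give a step within the scatter with a simple amine, a carboxylic acid or a longer alkyl chain in place of the benzoyl group. Among the compounds shown here, it also remains open whether the exchange of 1,3-oxazol-2-yl for benzoyl would give a comparable step on a core other than the one shared by compound 1 and compound 4.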